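The source may hold more compounds than are shown below. What is called first, only, known or untested is meant among the compounds shown, and "the series" means these compounds.

Measured so far in a functional assay on CWR22R cells (Homo sapiens) for antiproliferative activity, read by CCK-8 assay, with a stated time of 6 days; on this read-out lower numbers stand for stronger inhibition and higher numbers for weaker inhibition:
- compound 1 `CCN(c1ccc(C#N)c(Cl)c1)c1cc(-c2ccccc2)ccc1C`: > 30000 nM
- compound 2 `CCN(c1cccc(-c2ccccc2)c1)c1ccc(C#N)c(Cl)c1`: "not determined" (no result reported)
- compound 3 `CCN(c1cccc(-n2ccnc2)c1)c1ccc(C#N)c(C(F)(F)F)c1`: 19000 nM

Compound 1 gives only a limit in this assay, > 30000 nM, and no number. That is the position of compound 1 among the values shown: one of the three entries sits at the limit (the limit of > 30000 nM in this assay, at which 1 of the 3 values shown sits). A second entry, compound 2, carries no result at all, and only compound 3 has a single number, 19000 nM. Among the measured compounds shown here, no pair of measured compounds differs in one place, so no measured step is available.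

The unmeasured compound 4 `CCN(c1ccc(C#N)c(Cl)c1)c1cc(-n2cnc3ccccc32)ccc1C` differs from compound 1 by 1H-benzimidazol-1-yl in place of phenyl on an aromatic carbon. For the measured compounds named here, with no measured step of this kind and compound 1 itself at a limit, the size of the step cannot be read from the data; a move towards stronger inhibition beyond the scatter is expected, but with little confidence. Going by the values given here, the expectation leans on compound 3 as the only compound here with a nitrogen-containing aromatic ring and a number, 19000 nM. Compound 4 is estimated at 8000 nM, within 2000 nM to 30000 nM. This estimate means a step of an at least 3.7-fold lower number from compound 1 to compound 4 (0.57 log units; beyond the scatter).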

Compound 4, half-maximal inhibitory concentration: 3040 nM
For compound 4 the middle estimate is 2.6-fold (0.42 log units) above the measured one, within the range that was stated.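

Working notes on the position para to a methyl group on the core of compound 1: in this assay, 1H-benzimidazol-1-yl in place of phenyl gives an at least 9.8-fold lower number from compound 1 to compound 4 (0.99 log units; beyond the scatter). Among the compounds shown here, this is the first single-place change, and it shows that the group at this aromatic carbon can move the read-out beyond the scatter. The entering group brings two ring nitrogens and a second ring, and the size of the step has only a lower bound because compound 1 stands at a limit and has no single number: the limit of > 30000 nM in this assay, at which 1 of the 4 values shown sits.

The compounds shown do not separate the part played by the five-membered ring from that of the fused carbon ring. From the compounds shown here alone, how a simple amine, a carboxylic acid or a morpholine ring would read at this position also remains open.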